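From 4-fluorophenyl to 4-chlorophenyl on a shared core

A few compounds are considered here, and "the series" means these few. Any claim that something is new, unique, unknown or untested is made for them only; others in the source may bear on it.

Three compounds have been measured in a functional assay on A549 cells (Homo sapiens) for cytotoxicity, read by MTT assay, with a stated time of 72 h (a higher number here means a weaker inhibitor, a lower number a stronger inhibitor), so far:
- compound 1 `Cn1ccc2c(Oc3ccc(NC(=O)c4cc5cccnc5n(-c5ccc(Cl)cc5)c4=O)cc3F)ncnc21` gives 55500 nM
- compound 2 `O=C(Nc1ccc(Oc2ncnc3[nH]ccc23)c(F)c1)c1cc2cccnc2n(-c2ccccc2)c1=O` gives 45500 nM
- compound 3 `O=C(Nc1ccc(Oc2ncnc3[nH]ccc23)c(F)c1)c1cc2cccnc2n(-c2ccc(F)cc2)c1=O` gives 5290 nM

Compound 3 has the lowest number of the three, and both other compounds lie clearly above it. Compound 4 `O=C(Nc1ccc(Oc2ncnc3[nH]ccc23)c(F)c1)c1cc2cccnc2n(-c2ccc(Cl)cc2)c1=O` has not yet been measured. It differs from compound 3 by chloro in place of fluoro on an aromatic carbon with chloro in place of fluoro on an aromatic carbon, para to a large group.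

For the measured compounds named here, no measured pair exchanges fluoro for chloro, so the evidence is indirect. Going by the values given here, the one measured step at this place is an 8.6-fold lower number from compound 2 to compound 3 (0.93 log units; beyond the scatter) for fluoro in place of hydrogen on an aromatic carbon. That step shows the number can respond to a change here, but it does not show how chloro compares with fluoro. Compound 1 carries the same 4-chlorophenyl group and gives 55500 nM on a different core, which offers only a loose hint toward a higher number.

A small rise in this assay is therefore expected, possibly no larger than the scatter. The expected change is a 1.7-fold higher number from compound 3 to compound 4 (0.23 log units; within the scatter) with a wide margin on either side. Compound 4 is estimated at 9000 nM with a range from 2500 nM to 32000 nM in this estimate.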

Compound 4, half-maximal inhibitory concentration: 35500 nM
Estimate against measurement, compound 4: 3.9-fold (0.60 log units) below, outside the stated range (above it).
By their numbers in this assay, from the lowest: compound 3; then compounds 4, 2 and 1 (each within the scatter of the next).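

In this assay, fluoro and chloro at this place, para to a large group, are not interchangeable: the exchange gives a 6.7-fold higher number from compound 3 to compound 4 (0.83 log units; beyond the scatter). Chloro in place of hydrogen on the same carbon gives a 1.3-fold lower number from compound 2 to compound 4 (0.11 log units; within the scatter), so chloro does not repeat the step seen with fluoro, an 8.6-fold lower number from compound 2 to compound 3 (0.93 log units; beyond the scatter), and among the three groups compared here on the shared core, only the 4-fluorophenyl compound stands apart from the other two. The last new comparison, at a different place, gives a 1.6-fold lower number from compound 1 to compound 4 (0.19 log units; within the scatter) for hydrogen in place of methyl on an aromatic nitrogen, so with the 4-chlorophenyl group present, that methyl leaves the number within the scatter.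

The compounds shown offer no measurement that accounts for the difference between fluoro and chloro at this position. As far as these compounds go, it remains open how a bromo, methoxy or trifluoromethyl group would read at this place, and whether the methyl on the aromatic nitrogen would also leave the number within the scatter when paired with the 4-fluorophenyl group.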